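A few compounds are considered here, and "the series" means these few. Any claim that something is new, unique, unknown or untested is made for them only; others in the source may bear on it.

Working notes on the series. In a functional assay on the whole organism (strain Wistar Albino) for inhibition, with Rattus norvegicus as the target, read by paw edema, with a stated time of 3 h, at a dose of 20 mg/kg (on this read-out higher numbers stand for more inhibition at the one dose given (going by the name of the read-out) and lower numbers for less inhibition), compound 1 `COc1ccc(Cc2nnc3n2NC(c2ccc([N+](=O)[O-])o2)S3)cc1OC` gives 21.4%. Compound 2 `COc1ccc(Cc2nnc3n2NC(c2ccc[nH]2)S3)cc1OC` differs from compound 1 only in the group on the saturated ring carbon; in this assay compound 2 gives 17.7%. Going by the values given here, the one measured step, a number 3.7 percentage points lower from compound 1 to compound 2 (within the scatter), therefore changes nothing beyond the scatter, and compound 2 stands within the scatter of compound 1, the only other number measured, so no order between the two can be stated.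

Compound 3 `COc1ccc(Cc2nnc3n2NC(c2cccn2C)S3)cc1OC` is the next member. It differs from compound 2 by methyl in place of hydrogen on an aromatic nitrogen. Among the compounds with values here, no measured step of the same kind exists: the only step in hand swaps one aryl group for another on the saturated ring carbon, and even that swap gave a number 3.7 percentage points lower from compound 1 to compound 2 (within the scatter). Nothing in the numbers suggests that adding a methyl on the aromatic nitrogen would move this assay beyond the scatter, so the step of a number 1.3 percentage points higher from compound 2 to compound 3 (within the scatter) is expected to be small in either direction. The estimate for compound 3 in this assay is 19%, within 9% to 29%.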

Compound 3, a percentage reported as inhibition, in the whole organism at one dose (the size of the read-out at that dose, not a potency): 18.4%
The estimate for compound 3 lay 0.6 percentage points above the measured number; the measured number falls inside the stated range.
By their numbers in this assay, from the lowest: compounds 2, 3 and 1 (each within the scatter of the next).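

Methyl in place of hydrogen on an aromatic nitrogen, a position the earlier pair did not touch, gives a number 0.7 percentage points higher from compound 2 to compound 3 (within the scatter) in this assay, so in this one pair the hydrogen on that nitrogen can be replaced by methyl with no difference beyond the scatter. The swap of 1-methyl-1H-pyrrol-2-yl for 5-nitrofuran-2-yl on a saturated ring carbon gives a number 3 percentage points lower from compound 1 to compound 3 (within the scatter), which makes a second exchange at that carbon that stays inside the scatter, and no order can be stated among the three compounds at this one dose. Nothing at hand bears on the reason for these small steps.

Whether a larger group on the aromatic nitrogen, such as benzyl or a longer chain, would still stay inside the scatter remains open, since methyl is the only replacement shown there. Also open, as far as these compounds go, is whether a phenyl ring carrying an amine or a carboxylic acid on the saturated ring carbon would move this read-out beyond the scatter, in either direction, from the level of these three compounds.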